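The compounds below may be only part of what the source reports. "The series", "measured", "known", "first", "only" and "open" are said of these compounds alone.

In a functional assay on HOS cells (Homo sapiens) for antiproliferative activity, with a stated time of 72 h (on this read-out lower numbers stand for stronger inhibition and higher numbers for weaker inhibition), the shared core of this small set carries a benzyl group on a nitrogen on an aromatic ring, and only the halogens on that benzyl group change from compound to compound. Compound 1 `OC[C@H]1O[C@@H](n2cnc3c(NCc4ccc(Cl)cc4)ncnc32)[C@H](O)[C@@H]1O` carries a 4-chlorobenzyl group; in this assay compound 1 reaches only a limit, > 166000 nM. Compound 2 `OC[C@H]1O[C@@H](n2cnc3c(NCc4ccc(Br)cc4)ncnc32)[C@H](O)[C@@H]1O` carries a 4-bromobenzyl group; in this assay compound 2 likewise reaches only a limit, > 166000 nM. The step from compound 1 to compound 2 in this assay, a step that the two limits leave unreadable from compound 1 to compound 2, cannot be sized, since both values are limits. Compound 3 `OC[C@H]1O[C@@H](n2cnc3c(NCc4c(F)ccc(F)c4F)ncnc32)[C@H](O)[C@@H]1O` carries a benzyl group with three fluorines; in this assay compound 3 has "not determined" (no result reported).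

So compound 2 stands at a limit, among three values of which two are limits and one carries no number at all. For the measured compounds named here, the one measured step bearing on the change is unreadable, and the only evidence is the limit of > 166000 nM in this assay, at which 2 of the 3 values shown sit.

Compound 4 `OC[C@H]1O[C@@H](n2cnc3c(NCc4ccc(F)cc4Cl)ncnc32)[C@H](O)[C@@H]1O` differs from compound 2 by 2-chloro-4-fluorophenyl in place of 4-bromophenyl on a saturated chain carbon bound to a nitrogen on an aromatic ring. Because of the limit of > 166000 nM in this assay, at which 2 of the 3 values shown sit, compound 4 is expected to sit near that same limit. The expected step comes to a step that the limit leaves unreadable from compound 2 to compound 4, nothing readable beyond the scatter. For compound 4 the estimate is 200000 nM, ranging from 40000 nM to 1000000 nM.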

Compound 4, half-maximal inhibitory concentration: > 166000 nM
Compound 4: no number, only a limit (the forecaster's own chance of this, stated with the estimate: 80%); the middle value lies beyond the limit too.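

Compound 4, like compound 1 and compound 2, gives only a limit in this assay, so the steps from compound 1 and from compound 2 to compound 4 cannot be read: the limit of > 166000 nM in this assay, at which 3 of the 4 values shown sit.

The compounds shown leave open whether any halogen pattern on the benzyl group gives a real number on these cells, and how such patterns would then compare.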